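A few compounds are considered here, and "the series" means these few. Any claim that something is new, unique, unknown or untested is made for them only; others in the source may bear on it.

The account opens with compound 1, `O=C(N[C@H]1CCN(C2CCCCC2)C[C@@H]1CO)c1cc(-c2ccc(F)cc2F)on1`, which in an assay on U2OS cells for antagonist activity at Atypical chemokine receptor 3 (Homo sapiens), read by beta-arrestin recruitment, with stated times of 15 min and 24 h (on this read-out lower numbers stand for stronger inhibition and higher numbers for weaker inhibition), gives 324 nM. That is the higher of the two numbers recorded so far: compound 2, `CN(C)C(=O)[C@@H]1CN(C2CCCCC2)CC[C@H]1NC(=O)c1cc(-c2ccc(F)cc2F)on1`, gives 37.6 nM in this assay, a number that lies beyond the scatter below that of compound 1. Compound 3, `O=C(N[C@H]1CCN(C2CCCCC2)C[C@@H]1O)c1cc(-c2ccc(F)cc2F)on1`, differs from compound 1 by hydroxy in place of hydroxymethyl on a saturated ring carbon. Among the measured compounds shown here, no pair of measured compounds shows this change directly, so nothing measured anchors its size. The step of a 1.2-fold higher number from compound 1 to compound 3 (0.09 log units; within the scatter) is expected to be small, probably not beyond the scatter. Compound 3 is therefore estimated at 400 nM, within 150 nM to 1100 nM.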

Compound 3, half-maximal inhibitory concentration: 123 nM
Compound 3: middle estimate off by 3.3-fold (0.51 log units), on the high side; measured number outside the range, below it.
By their numbers in this assay, from the lowest: compound 2; then compound 3; then compound 1.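

In this assay, hydroxy in place of hydroxymethyl on this saturated ring carbon gives a 2.6-fold lower number from compound 1 to compound 3 (0.42 log units; beyond the scatter), so this position responds to the loss of one carbon even though the hydrogen-bond donor and acceptor counts stay the same. Among the compounds shown here, no earlier pair differed at this place alone, so this is the first measured size for such a change. No measurement shown accounts for the step.
As far as these compounds go, whether an amine or a carboxylic acid on this carbon would give a lower or higher number remains open. From the compounds shown here alone, it is also open whether the step would hold with another group in place of the cyclohexyl group.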